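This account rests on a few compounds, and the source may have more. Where it says the series, first, only, none or still open, it means among the compounds named here.

Measured so far:
compound 1, `COc1ccc(Br)cc1CCc1c(F)cccc1C(=O)/N=C(\N)NCC(C)C` — 8500 nM
compound 2, `CCN(CC)CCCC(C)/N=C(/N)NC(=O)c1cccc(F)c1CCc1ccc2ccccc2c1` — 1800 nM
compound 3, `CCN(CC)CCCC(C)/N=C(/N)NC(=O)c1cccc(F)c1OCc1cc(Br)ccc1OC` — 530 nM

In a functional assay for antagonist activity at Melanocortin receptor 4 (Homo sapiens), read by cAMP accumulation (a higher number here means a weaker inhibitor, a lower number a stronger inhibitor), compound 1 gives 8500 nM, the highest of the three numbers. Compound 2 lies nearest to it with 1800 nM, and compound 3 furthest with 530 nM; both gaps to compound 1 are beyond the usual scatter of this assay. No pair of these compounds differs in a single place, so no single step can be read from them directly.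

Compound 4, `COc1ccc(Br)cc1CCc1c(F)cccc1C(=O)/N=C(\N)NCCCCN1CCCCC1`, keeps the core of compound 1 and differs from it in one place: 3-(piperidin-1-yl)propyl in place of isopropyl on a saturated chain carbon bound to an amine nitrogen. For the measured compounds named here, compounds 2 and 3 both carry a longer chain ending in an amine, and both sit well below compound 1 in this assay, which is the only guide available for the effect of such a chain.

Compound 4 is therefore expected to show a lower number than compound 1, with a step of a 5.7-fold lower number from compound 1 to compound 4 (0.75 log units; beyond the scatter) that should exceed the scatter, because compound 3 gives 530 nM and compound 2 gives 1800 nM where compound 1 gives 8500 nM. The estimate for compound 4 in this assay is 1500 nM, within a range from 400 nM to 5000 nM.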

Compound 4, half-maximal inhibitory concentration: 70 nM
Estimate against measurement, compound 4: 21-fold (1.33 log units) above, outside the stated range (below it).
By their numbers in this assay, from the lowest: compound 4; then compound 3; then compound 2; then compound 1.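

In this assay, putting 3-(piperidin-1-yl)propyl in place of isopropyl on a saturated chain carbon bound to an amine nitrogen gives a 120-fold lower number from compound 1 to compound 4 (2.08 log units; beyond the scatter), a large step and the first effect of a single change that can be read from these compounds. With the core of compound 1 kept, this place accepts a group of 9 heavy atoms instead of 3, including a nitrogen and a six-membered non-aromatic ring, and the number falls rather than rises, so the read-out is highly sensitive to what stands here. Nothing available bears on why the step is so large.

The change alters chain size, ring and nitrogen all at once, so the compounds shown cannot assign the step to any one of these features, and this one pair cannot show whether the same step would hold on another core. Open questions are how an unbranched butyl chain without nitrogen, a chain ending in a primary amine or diethylamino group, or a 3-morpholinopropyl group would read at this place.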